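This account rests on a few compounds, and the source may have more. Where it says the series, first, only, none or still open, it means among the compounds named here.

Measured in a functional assay on KB cells (Homo sapiens) for cytotoxicity (a lower number here means that less compound is needed, a higher number that more compound is needed for the effect), so far:
compound 1 `COC1=C(C)C(=O)/C(=C(O)/C=C/c2ccc(C)cc2)C(=O)C1(C)C`: 3.9 ug/mL
compound 2 `CCc1ccc(/C=C/C(O)=C2/C(=O)C(C)=C(OC)C(C)(C)C2=O)cc1`: 6.9 ug/mL
compound 3 `CCC1=C(OC)C(CC)(CC)C(=O)C(C(=O)/C=C/c2ccc(C)cc2)=C1O`: 3 ug/mL

Compound 2 differs from compound 1 by methyl in place of hydrogen on a saturated chain carbon bound to an aromatic carbon; that step gave a 1.8-fold higher number from compound 1 to compound 2 (0.25 log units; within the scatter). Compound 3 is built on a different core; how its core differs from that of compound 1 is not broken down here. Its number in this assay and that of compound 1 lie within the scatter of each other, while compound 2 stands beyond the scatter from compound 3.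

Compound 4 `CCC1=C(OC)C(CC)(CC)C(=O)C(C(=O)/C=C/c2ccc(CC)cc2)=C1O` is not yet measured. It differs from compound 3 by methyl in place of hydrogen on a saturated chain carbon bound to an aromatic carbon, the same change as from compound 1 to compound 2, at the same place. For compound 4 the step expected in this assay is a 1.7-fold higher number from compound 3 to compound 4 (0.22 log units; within the scatter), because the same change gave a 1.8-fold higher number from compound 1 to compound 2 (0.25 log units; within the scatter). Compound 4 is thus expected to come out near 5 ug/mL, between 2.5 ug/mL and 10 ug/mL.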

Compound 4, concentration for half-maximal effect: 3.6 ug/mL
The estimate for compound 4 lay 1.4-fold (0.14 log units) above the measured number, and the stated range covers the measured number.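

In this assay, going from 4-methylphenyl to 4-ethylphenyl on the second core gives a 1.2-fold higher number from compound 3 to compound 4 (0.08 log units; within the scatter). Set beside the earlier step, the change carries from one core to the other with no difference that can be told apart: the same change on two cores in this assay, a 1.8-fold higher number (0.25 log units; within the scatter) from compound 1 to compound 2 and a 1.2-fold higher number (0.08 log units; within the scatter) from compound 3 to compound 4, 1.5-fold (0.17 log units) apart, within the scatter of two such steps. This shows agreement between two pairs only, with each step inside the scatter; it does not show that the change has a real effect on either core, or that a third core would behave alike.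

The compounds shown leave open whether a longer chain, such as butyl, in place of the ethyl would move the number beyond the scatter. On these data alone, an amine or a carboxylic acid on that carbon also remains open.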